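The source may report more compounds than this note shows. Statements on the series, on what has been measured and on what is new or still open speak of the compounds shown alone.

The measured compounds and their values:

Compound 1, `Cc1ccccc1/N=N/C(=N/NC(=O)c1cc(O)c(O)c(O)c1)c1ccccc1`, in an ADME assay on RAW264.7 cells (Mus musculus) for inhibition, read by MTT assay, with a stated time of 72 h, tested at 100 uM; on this read-out lower numbers stand for less inhibition of growth and higher numbers for more inhibition of growth at the one concentration tested: 41.5%
Compound 2, `O=C(N/N=C(/N=N/c1ccccc1)c1ccccc1)c1cc(O)c(O)c(O)c1`, in this assay: 41.4%
Compound 3, `O=C(N/N=C(/N=N/c1ccc(Cl)cc1Cl)c1ccccc1)c1cc(O)c(O)c(O)c1`, in this assay: 21.5%

Compound 1 carries the highest number of the three, but compound 2 sits within the scatter of it: a number 0.1 percentage points lower from compound 1 to compound 2 (within the scatter). Only compound 3 stands clearly apart, with a number 20 percentage points lower from compound 1 to compound 3 (beyond the scatter) and a number 19.9 percentage points lower from compound 2 to compound 3 (beyond the scatter).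

The unmeasured compound 4, `O=C(N/N=C(/N=N/c1ccccc1[N+](=O)[O-])c1ccccc1)c1cc(O)c(O)c(O)c1`, differs from compound 1 in one place: nitro in place of methyl on an aromatic carbon.

For the measured compounds named here, no measured step exchanges a methyl for a nitro, so the bearing of the known steps is indirect. The step from compound 1 to compound 2 shows that removing the methyl changes nothing beyond the scatter, while the two steps to compound 3 show that a more heavily substituted phenyl on the double-bonded nitrogen lowers the number by a modest amount. A change of either kind, or none beyond the scatter, is therefore plausible for compound 4, and the estimate must stay wide. For compound 4 the step expected is a number 7.5 percentage points lower from compound 1 to compound 4 (within the scatter). Compound 4 is estimated at 34%, with a range from 15% to 52%.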

Compound 4, percent growth inhibition at one concentration: 5.43%
Beside the measured number, compound 4's estimate is 28.6 percentage points above it; measured number outside the range, below it.
By their numbers in this assay, from the lowest: compound 4; then compound 3; then compounds 2 and 1 (each within the scatter of the next).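

In this assay the aromatic carbon ortho to a large group turned out not to be indifferent to its substituent: hydrogen in place of methyl had given only a number 0.1 percentage points lower from compound 1 to compound 2 (within the scatter) but nitro there gives a number 36.1 percentage points lower from compound 1 to compound 4 (beyond the scatter) and, measured against hydrogen, a number 36 percentage points lower from compound 2 to compound 4 (beyond the scatter) as well. The 2-nitrophenyl group also goes further than 2,4-dichlorophenyl, with a number 16.1 percentage points lower from compound 3 to compound 4 (beyond the scatter) so the earlier fall with 2,4-dichlorophenyl did not mark the lowest number this ring can give. Nothing measured here bears on why nitro differs so much from methyl at this position.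

The compounds shown leave open whether the fall belongs to nitro alone or would also follow from an amine or a carboxylic acid on the same carbon. They also leave open whether nitro elsewhere on this ring would give a similar number.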